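The source may report more compounds than this note shows. Statements on the series, on what has been measured and on what is new or still open speak of the compounds shown alone.

Compound 1 `COC(=O)CCCn1nnnc1[C@@H](COCc1ccccc1)NC(=O)C(C)(C)N` and compound 2 `CC(C)(N)C(=O)N[C@H](COCc1ccccc1)c1nnnn1CCC(=O)NCc1ccccc1` share a core and differ only at the end of the chain that hangs from the aromatic nitrogen. In a functional assay on H4 cells for agonist activity at growth hormone secretagogue receptor type 1 (Homo sapiens), read by FLIPR (on this read-out higher numbers stand for an effect only at larger amounts of compound and lower numbers for an effect already at smaller amounts), compound 1 gives 55 nM, and in this assay compound 2 gives 51 nM. The step of a 1.1-fold lower number from compound 1 to compound 2 (0.03 log units; within the scatter) shows that this tail can be rebuilt without a change beyond the scatter. Compound 2 stands with the lowest of the two numbers, though its gap to compound 1 is within the scatter, so neither can be called the more potent.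

Compound 3 `CC(C)(N)C(=O)N[C@H](COCc1ccccc1)c1nnnn1CCC(=O)NCCCc1ccccc1` takes the next step: phenethyl in place of phenyl on a saturated chain carbon bound to an amide-type nitrogen. Among the compounds with values here, only the step from compound 1 to compound 2 bears on this region, and it was flat; it does not tell how a longer link between the amide-type nitrogen and the ring will fare. Given the tolerance already seen in a 1.1-fold lower number from compound 1 to compound 2 (0.03 log units; within the scatter), compound 3 is expected to stay near compound 2, with a 1.4-fold higher number from compound 2 to compound 3 (0.14 log units; within the scatter) as the most likely outcome. The estimate for compound 3 in this assay is therefore 70 nM, expected to fall between 25 nM and 200 nM.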

Compound 3, half-maximal effective concentration: 59 nM
Compound 3: the middle estimate sits 1.2-fold (0.07 log units) above what was measured; measured number inside the range.
By their numbers in this assay, from the lowest: compounds 2, 1 and 3 (each within the scatter of the next).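

In this assay, the step of a 1.2-fold higher number from compound 2 to compound 3 (0.06 log units; within the scatter) shows that phenethyl can take the place of phenyl on this saturated chain carbon bound to an amide-type nitrogen without a change beyond the scatter, so benzylcarbamoyl and (3-phenylpropyl)carbamoyl cannot be told apart here. The comparison with the ester tail gives the same reading, with a 1.1-fold higher number from compound 1 to compound 3 (0.03 log units; within the scatter) when (3-phenylpropyl)carbamoyl stands in place of (methoxycarbonyl)methyl, and so all three tails on the shared core remain within the scatter of one another. No other measurement accompanies these numbers, and nothing here offers an explanation for this flat result.

The compounds shown leave open whether the numbers would stay level with a still longer chain, or with a carboxylic acid or a primary amine at the end of the tail in place of the phenyl ring. Within the data shown here, they also do not tell whether a phenyl ring carrying fluorine or a methoxy group would bring the first step beyond the scatter at this position.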